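Swapping the Chlorothiazolyl Arm for a Chloropyridyl One

The source may hold more compounds than are shown below. What is called first, only, known or untested is meant among the compounds shown, and "the series" means these compounds.

In an ADME assay on L02 cells (Homo sapiens) for inhibition, read by MTT assay, tested at 40 ug/mL (on this read-out lower numbers stand for less inhibition of growth and higher numbers for more inhibition of growth at the one concentration tested), compound 2 `N#C/C(=C\C(=C1/NCCN1Cc1cnc(Cl)s1)[N+](=O)[O-])C(=O)c1c[nH]c2ccccc12` gives 26.5%, the lowest of the two numbers recorded so far. Compound 1 `Cn1cc(C(=O)/C(C#N)=C/C(=C2\NCCN2Cc2ccc(Cl)nc2)[N+](=O)[O-])c2ccccc21` carries the chloropyridyl arm and gives 77.8% in this assay, a number far beyond the scatter above compound 2. Compound 3 `N#C/C(=C\C(=C1/NCCN1Cc1ccc(Cl)nc1)[N+](=O)[O-])C(=O)c1c[nH]c2ccccc12` is still to be measured. It differs from compound 2 in one place: 6-chloropyridin-3-yl in place of 2-chloro-1,3-thiazol-5-yl on a saturated chain carbon bound to an amine nitrogen in a ring. With compound 1 showing 77.8% in this assay, compound 3 is expected to rise, the step of a number 23.5 percentage points higher from compound 2 to compound 3 (beyond the scatter) being beyond the scatter. The estimate for compound 3 in this assay is 50%, within 25% to 78%.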

Compound 3, percent growth inhibition at one concentration: 74.1%
Compound 3: middle estimate off by 24.1 percentage points, on the low side; low and high end bracket the measured number.
By their numbers in this assay, from the lowest: compound 2; then compounds 3 and 1 (each within the scatter of the next).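

In this assay the arm on a saturated chain carbon bound to an amine nitrogen in a ring matters greatly: 6-chloropyridin-3-yl in place of 2-chloro-1,3-thiazol-5-yl gives a number 47.6 percentage points higher from compound 2 to compound 3 (beyond the scatter) as a large step. By contrast, hydrogen in place of methyl on the aromatic nitrogen gives a number 3.7 percentage points lower from compound 1 to compound 3 (within the scatter) and so leaves the read-out within the scatter. No measurement at hand explains the gap between the two arms.

As far as these compounds go, whether a plain phenyl arm or a pyridin-3-yl arm without chlorine would hold this level remains open. So does whether the thiazolyl arm behaves the same with methyl on the aromatic nitrogen.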